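Removing the side chain from compound 3

The source may report more compounds than this note shows. Statements on the series, on what has been measured and on what is new or still open speak of the compounds shown alone.

Values measured so far in a functional assay on SMMC-7721 cells (Homo sapiens) for antiproliferative activity, read by MTT assay, with a stated time of 48 h (a lower number here means a stronger inhibitor, a higher number a weaker inhibitor), are all limits and not numbers.
- compound 1 `Cn1cc(C2=C(c3nn(CCCn4ccnc4)c4ncccc34)C(=O)NC2=O)c2ccccc21` gives > 100000 nM as a limit
- compound 2 `CN1CCN(CCCn2nc(C3=C(c4cn(C)c5ccccc45)C(=O)NC3=O)c3cccnc32)CC1` gives > 100000 nM as a limit
- compound 3 `CN(C)CCCn1nc(C2=C(c3cn(C)c4ccccc34)C(=O)NC2=O)c2cccnc21` gives > 100000 nM as a limit

Compound 3 has only a limit and no number to place it. Within the data shown here, the series so far stands at the limit of > 100000 nM in this assay, at which 3 of the 3 values shown sit, and offers no finer reading.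

Compound 4 `Cn1cc(C2=C(c3n[nH]c4ncccc34)C(=O)NC2=O)c2ccccc21` carries hydrogen in place of 3-(dimethylamino)propyl on an aromatic nitrogen and so loses the whole chain.

The nearest measured changes alter only the group at the end of that chain. They are a step that the two limits leave unreadable from compound 1 to compound 2 and a step that the two limits leave unreadable from compound 1 to compound 3 and also a step that the two limits leave unreadable from compound 2 to compound 3 with the chain kept each time. Among the measured compounds shown here, none of them yields a size, and no measured compound lacks the chain, so no size carries over to this change.

Any readable number for compound 4 in this assay would have to lie on the stronger side of the limit, so the expectation leans that way, and another limit remains quite possible. The estimated step is an at least 2.0-fold lower number from compound 3 to compound 4 (0.30 log units; that floor lies within the scatter) and it is loosely held. For compound 4 the expected value is 50000 nM with an estimated range from 8000 nM to 150000 nM in this reading.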

Compound 4, half-maximal inhibitory concentration: > 100000 nM
Compound 4: a limit, no number; the forecaster's own chance of this, stated with the estimate: 55%; at least 2.0-fold (0.30 log units) between middle value and limit.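

In this assay, among these compounds, compound 4 gives > 100000 nM, a limit and not a number, so no step from compound 1, compound 2 or compound 3 to compound 4 can be read. The series stands at a single reading: the limit of > 100000 nM in this assay, at which 4 of the 4 values shown sit.

The compounds shown leave open whether removing the chain or changing its end group alters activity at all.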